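Aryl group swap on the shared core: compound 3

The source may report more compounds than this note shows. Statements on the series, on what has been measured and on what is new or still open speak of the compounds shown alone.

Two compounds of the series have numbers in an assay for binding affinity to dual specificity mitogen-activated protein kinase kinase 4 (Homo sapiens), read by KINOMEscan, tested at 100 nM; on this read-out lower numbers stand for a stronger effect and higher numbers for a weaker effect at the one concentration tested. Compound 1 `CCCS(=O)(=O)Nc1ccc(F)c(C(=O)c2n[nH]c3ncc(-c4ccccc4Cl)cc23)c1F` gives 9.3%. Compound 2 `CCCS(=O)(=O)Nc1ccc(F)c(C(=O)c2n[nH]c3ncc(-c4ccc(F)cc4)cc23)c1F` gives 2.1%, the lowest of the two numbers, with compound 1 nearest at a number 7.2 percentage points lower from compound 1 to compound 2 (within the scatter). The sole difference between them is 4-fluorophenyl in place of 2-chlorophenyl on an aromatic carbon of the shared core.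

Compound 3 `CCCS(=O)(=O)Nc1ccc(F)c(C(=O)c2n[nH]c3ncc(-c4ccccc4C)cc23)c1F` is not yet measured. Against compound 2 it shows (2-methylphenyl in place of 4-fluorophenyl on an aromatic carbon). Among the measured compounds shown here, the only step that bears on this change is the one from compound 1 to compound 2, which carries a different aryl group on the same aromatic carbon and amounts to a number 7.2 percentage points lower from compound 1 to compound 2 (within the scatter), within the scatter. For the measured compounds named here, with that as the only guide, no step beyond the scatter is expected in this assay. For compound 3 the expected value is 6%, with a range of 1% to 20%. This estimate means a step of a number 3.9 percentage points higher from compound 2 to compound 3 (within the scatter), expected to stay within the scatter.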

Compound 3, a percentage reported as activity, at one concentration (the size of the read-out at that concentration, not a potency): 7%
Estimate against measurement, compound 3: 1 percentage points below, and the stated range covers the measured number.
By their numbers in this assay, from the lowest: compounds 2, 3 and 1 (each within the scatter of the next).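

On this aromatic carbon, two atoms from the ring nitrogen, 2-methylphenyl in place of 4-fluorophenyl gives in this assay a number 4.9 percentage points higher from compound 2 to compound 3 (within the scatter) and thus adds a third aryl group with no step beyond the scatter. Methyl in place of chloro on the same aryl frame gives a number 2.3 percentage points lower from compound 1 to compound 3 (within the scatter) and shows that this read-out does not separate 2-methylphenyl from 2-chlorophenyl. Nothing available explains why these aryl groups read alike.

As far as these compounds go, all three groups here are singly substituted phenyl rings, so it stays open whether a pyridine ring, a phenyl ring carrying a carboxylic acid or an amine, or a non-aromatic group such as cyclopropyl would hold the number at this position. A read-out at one concentration also tells only the size of the effect of all three compounds at that concentration.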